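From a Fluorophenyl to a Chlorophenyl Substituent

A few compounds are considered here, and "the series" means these few. Any claim that something is new, unique, unknown or untested is made for them only; others in the source may bear on it.

In a functional assay on CHO cells for agonist activity at adenosine receptor A1 (Homo sapiens), read by fluorescence and ERK phosphorylation, with stated times of 30 min and 1.5 h, tested at 10 uM (on this read-out lower numbers stand for a weaker effect and higher numbers for a stronger effect at the one concentration tested), compound 1 `Nc1scc(-c2cccc(C(F)(F)F)c2)c1C(=O)c1ccccc1` gives 59%, and compound 2 `Nc1scc(-c2cccc(F)c2)c1C(=O)c1ccccc1` gives 52%. Within the data shown here, the only measured step, a number 7 percentage points lower from compound 1 to compound 2 (within the scatter), lies within the scatter. Compound 2 thus holds the lower of the two numbers, but it is not separated from compound 1 beyond the scatter. Compound 3 `Nc1scc(-c2ccc(Cl)cc2)c1C(=O)c1ccccc1` has not yet been measured; it differs from compound 2 by 4-chlorophenyl in place of 3-fluorophenyl on an aromatic carbon. Among the measured compounds shown here, no measured step bears directly on this change: the one step known, a number 7 percentage points lower from compound 1 to compound 2 (within the scatter), replaces one group with another on an aromatic carbon and stayed within the scatter. With nothing pointing to a shift, the step expected for compound 3 in this assay is no change at the digits printed from compound 2 to compound 3 (within the scatter), a change within the scatter. Compound 3 is therefore estimated at 52%, with a range from 30% to 74%.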

Compound 3, a percentage reported as activity, at one concentration (the size of the read-out at that concentration, not a potency): 51%
Compound 3: middle estimate off by 1 percentage points, on the high side; the measured number falls inside the stated range.
By their numbers in this assay, from the lowest: compounds 3, 2 and 1 (each within the scatter of the next).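

In this assay, putting 4-chlorophenyl in place of 3-fluorophenyl on the aromatic carbon two ring bonds from the ring sulfur gives a number 1 percentage points lower from compound 2 to compound 3 (within the scatter). This is the second step at this position to stay within the scatter, and here the group changes both its halogen and the place of that halogen on the phenyl ring, so a halogen exchange and a shift of place together still leave the read-out unmoved beyond the scatter. Nothing given here accounts for this result.

As far as these compounds go, the two changes made at once in this step cannot be told apart, so it remains open whether either would act alone. From the compounds shown here alone, it also remains open how this assay would respond to an amine, a carboxylic acid or a longer chain on the phenyl ring.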